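A few compounds are considered here, and "the series" means these few. Any claim that something is new, unique, unknown or untested is made for them only; others in the source may bear on it.

Of the compounds shown here, two have so far been tested in a toxicity assay on THP-1 cells (Homo sapiens) for inhibition; a higher number here means that more compound is tolerated, a lower number that less compound is tolerated. Compound 1 `Cn1c(-c2ccc(Br)cc2)cnc1NC(=O)c1ccc(F)cc1` stands highest of the two, and in this assay compound 1 gives 46000 nM. The other measured compound, compound 2 `O=C(Nc1ncc(-c2ccccc2)o1)c1ccc(Cl)cc1`, is built around a different five-membered ring and in this assay compound 2 gives 10000 nM, a lower number than that of compound 1 by a gap that lies beyond the usual scatter of repeated measurements. For the measured compounds named here, no pair of measured compounds differs in a single place, so there is no measured step to lean on.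

Compound 3 `Cn1c(-c2ccccc2Br)cnc1NC(=O)c1ccc(F)cc1` has not yet been measured. It differs from compound 1 in one spot: 2-bromophenyl in place of 4-bromophenyl on an aromatic carbon. The same atoms are present in both; only the position of the bromine on the phenyl ring moves. Going by the values given here, with no comparable step available, the expectation for compound 3 is a change no larger than the scatter, with the step of a 1.2-fold lower number from compound 1 to compound 3 (0.06 log units; within the scatter) expected to be small and in no firm direction. Compound 3 is estimated to give 40000 nM, within a range from 15000 nM to 100000 nM.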

Compound 3, half-maximal cytotoxic concentration: > 100000 nM
Compound 3: only a limit was reported (the forecaster's own chance of this, stated with the estimate: 25%); at least 2.5-fold (0.39 log units) between middle value and limit.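

Moving the bromine around the phenyl ring, with no atom added or taken away, is enough to change how much compound the cells tolerate in this assay: 2-bromophenyl in place of 4-bromophenyl gives an at least 2.1-fold higher number from compound 1 to compound 3 (0.33 log units; beyond the scatter). Compound 3 gives > 100000 nM, which is a limit of the assay and not a number. The group on this aromatic carbon, next to the ring atom that bears a methyl group, is therefore a place where the position of the bromine alone makes a difference beyond the scatter in this assay, and the printed step is only the smallest size it can have: the limit of > 100000 nM in this assay, at which 1 of the 3 values shown sits.

Going by these compounds, it remains open whether the same shift would appear with a different group on the phenyl ring, such as an amine or a carboxylic acid in place of the bromine, or with the phenyl ring attached to the five-membered ring of compound 2. This single pair also cannot tell why the number moves, or how far compound 3 really lies from compound 1.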